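This account rests on a few compounds, and the source may have more. Where it says the series, first, only, none or still open, it means among the compounds named here.

Of the compounds shown here, three of one shared core have been tested in an assay on membranes from HeLa cells for displacement of a labelled ligand from adenosine receptor A3 (Homo sapiens), read by scintillation counting, with a stated time of 180 min, tested at 1 uM; a higher number here means more inhibition at the concentration tested (going by the name of the read-out), a lower number less inhibition. Compound 1 `CC1=C(C(=O)OCc2ccccc2)C(c2ccsc2)NC(=O)N1` gives 25%. Compound 2 `CC1=C(C(=O)NC(C)C)C(c2ccsc2)NC(=O)N1` gives 1%. Compound 3 `CC1=C(C(=O)OC2CCCCC2)C(c2ccco2)NC(=O)N1` gives 4%. On these three numbers compound 3 stands second highest; its nearest neighbour is compound 2, whose value lies within the usual scatter of compound 3, so the two cannot be told apart, while compound 1 lies beyond the scatter and clearly above compound 3.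

Compound 4 `CC1=C(C(=O)OC2CCCCC2)C(c2ccsc2)NC(=O)N1` has not been measured in this assay. It differs from compound 3 in one place: thiophen-3-yl in place of furan-2-yl on a saturated ring carbon. Going by the values given here, the only measured compound carrying thiophen-3-yl with an ester, compound 1, gives 25%, which is the highest of the three, but no measured pair isolates this exchange, so the step it brings is unknown. Compound 4 is expected to give 12%, with a range from 0% to 30%. The expected step of a number 8 percentage points higher from compound 3 to compound 4 (within the scatter) is an upward one that may or may not reach beyond the scatter.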

Compound 4, a percentage reported as inhibition, at one concentration (the size of the read-out at that concentration, not a potency): 1%
Estimate against measurement, compound 4: 11 percentage points above, and the stated range covers the measured number.
By their numbers in this assay, from the lowest: compounds 2, 4 and 3 (each within the scatter of the next); then compound 1.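

With the cyclohexyl ester held fixed in this assay, thiophen-3-yl in place of furan-2-yl on the saturated ring carbon gives a number 3 percentage points lower from compound 3 to compound 4 (within the scatter) and so brings no readable change at this position. Going by these compounds alone, with thiophen-3-yl held fixed, cyclohexyl in place of benzyl on the oxygen gives a number 24 percentage points lower from compound 1 to compound 4 (beyond the scatter) and marks the benzyl ester of compound 1 as the one group here that stands clear of compound 4, whereas cyclohexyloxy in place of isopropylamino on the carbonyl carbon gives no change at the digits printed from compound 2 to compound 4 (within the scatter) and separates nothing. No measurement shown here explains the gain that goes with the benzyl group.

On these data alone, whether the ring exchange would stay this small alongside a benzyl ester remains open. So does how a phenyl ring on the saturated ring carbon, or an ethyl group on the ester oxygen, would read.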